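The source may report more compounds than this note shows. Statements on the series, on what has been measured and on what is new or still open speak of the compounds shown alone.

Measured compounds:
compound 1 `NCCCCCCOc1ccc2c(=O)c(-c3ccc(O)cc3)coc2c1` — 100 nM
compound 2 `CCOC(=O)COc1ccc2c(=O)c(-c3ccc(O)cc3)coc2c1` — 130 nM
compound 3 `O=c1c(-c2ccc(O)cc2)coc2cc(OCCCCCCCCCO)ccc12` — 700 nM

In an assay (Cricetulus griseus) for inhibition of aldehyde dehydrogenase, mitochondrial (Homo sapiens) (a lower number here means a stronger inhibitor, a higher number a weaker inhibitor), compound 1 gives the lowest of the three numbers, though compound 2 sits within the scatter of it, as a 1.3-fold higher number from compound 1 to compound 2 (0.11 log units; within the scatter) shows; compound 3 is the furthest away, a 7.0-fold higher number from compound 1 to compound 3 (0.85 log units; beyond the scatter), a modest step. Compound 2 and compound 3 are separated by a 5.4-fold higher number from compound 2 to compound 3 (0.73 log units; beyond the scatter).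

Compound 4 `O=C(O)COc1ccc2c(=O)c(-c3ccc(O)cc3)coc2c1` has not yet been measured. It differs from compound 1 as follows: carboxy in place of 5-aminopentyl on a saturated chain carbon bound to an oxygen on an aromatic ring. Among the compounds with values here, of the measured steps, the one from compound 1 to compound 2 bears most directly, since compound 2 carries ethoxycarbonyl at the same place where compound 4 carries carboxy; that step was a 1.3-fold higher number from compound 1 to compound 2 (0.11 log units; within the scatter), within the scatter. The step from compound 1 to compound 3, where the amino group was exchanged further along the chain, was modestly larger at a 7.0-fold higher number from compound 1 to compound 3 (0.85 log units; beyond the scatter). Replacing the 5-aminopentyl chain at the chain carbon bound to the aromatic oxygen by a short group has so far cost little, so compound 4 is expected to land near compound 1 and compound 2, with the step of a 2.0-fold higher number from compound 1 to compound 4 (0.30 log units; within the scatter) expected to be small and, if anything, toward a higher number. Compound 4 is therefore estimated at 200 nM in this assay, within a range of 80 nM to 600 nM.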

Compound 4, half-maximal inhibitory concentration: 1200 nM
Compound 4: the middle estimate sits 6.0-fold (0.78 log units) below what was measured; measured number outside the range, above it.
By their numbers in this assay, from the lowest: compounds 1 and 2 (each within the scatter of the next); then compounds 3 and 4 (each within the scatter of the next).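

In this assay, the ester and the acid now form a direct pair: hydrogen in place of ethyl on an oxygen next to a carbonyl group moves the number clearly (a 9.2-fold higher number from compound 2 to compound 4 (0.97 log units; beyond the scatter)), so the end of the short chain matters, which the close agreement of compound 1 and compound 2 had not revealed. The change of the 5-aminopentyl group to carboxy is the largest step in this set (a 12-fold higher number from compound 1 to compound 4 (1.08 log units; beyond the scatter)), so this place does not accept every short replacement as readily as compound 2 suggested. Chain length alone does not order the series, as compound 2 and compound 4 carry short chains yet differ clearly, whereas carboxy in place of 8-hydroxyoctyl leaves compound 3 and compound 4 within the scatter of each other (a 1.7-fold higher number from compound 3 to compound 4 (0.23 log units; within the scatter)).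

No supporting measurement accounts for the difference between the ethyl ester and the carboxy compound. Still open, from the compounds shown here alone, is whether an amide at the same place would stay with compound 2 or with compound 4, and whether a carboxylic acid on a longer chain would stay with compound 4 or with compound 1.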